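Methylsulfanyl for Methoxy on a Furan-Free Nucleoside Core

A few compounds are considered here, and "the series" means these few. Any claim that something is new, unique, unknown or untested is made for them only; others in the source may bear on it.

Compound 1 `COc1ncnc2c1c(-c1ccoc1)cn2[C@@H]1O[C@H](CO)[C@@H](O)[C@H]1O` gives 290 nM in a functional assay on HepG2 cells (Homo sapiens) for antiproliferative activity, read by XTT assay, with a stated time of 72 h; on this read-out lower numbers stand for stronger inhibition and higher numbers for weaker inhibition.
Compound 2 `CSc1ncnc2c1c(-c1ccoc1)cn2[C@@H]1O[C@H](CO)[C@@H](O)[C@H]1O` gives > 15000 nM in this assay, which is a limit of the assay rather than a number (the limit of > 15000 nM in this assay, at which 1 of the 3 values shown sits).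
Compound 3 `C#Cc1cn([C@@H]2O[C@H](CO)[C@@H](O)[C@H]2O)c2ncnc(OC)c12` gives 12700 nM in this assay.

From compound 1 to compound 2 the change is methylsulfanyl in place of methoxy on an aromatic carbon, and it brought an at least 51-fold higher number from compound 1 to compound 2 (1.71 log units; beyond the scatter). The two cores differ by ethynyl in place of furan-3-yl on an aromatic carbon, a change that brought a 44-fold higher number from compound 1 to compound 3 (1.64 log units; beyond the scatter). Compound 4 `C#Cc1cn([C@@H]2O[C@H](CO)[C@@H](O)[C@H]2O)c2ncnc(SC)c12` differs from compound 3 by methylsulfanyl in place of methoxy on an aromatic carbon, at a place described in the same words, so it is the same change seen on the other core. A step of a 6.3-fold higher number from compound 3 to compound 4 (0.80 log units; beyond the scatter) is expected, resting on an at least 51-fold higher number from compound 1 to compound 2 (1.71 log units; beyond the scatter). Compound 4 is therefore estimated at 80000 nM, most likely reported only as a limit.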

Compound 4, half-maximal inhibitory concentration: > 15000 nM
Compound 4: a limit, no number; the forecaster's own chance of this, stated with the estimate: 85%; the middle value lies beyond the limit too.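

Compound 4 gives > 15000 nM in this assay, which is a limit of the assay and not a number. Methylsulfanyl in place of methoxy on the core of compound 3 brings an at least 1.1-fold higher number from compound 3 to compound 4 (0.07 log units; that floor lies within the scatter), so a drop in activity as large as on the core of compound 1 is neither confirmed nor ruled out, and the step between compound 2 and compound 4 cannot be read at all. The change can therefore be compared across the two cores only as far as the limit allows: the same change on two cores in this assay, an at least 51-fold higher number (1.71 log units; beyond the scatter) from compound 1 to compound 2 and an at least 1.1-fold higher number (0.07 log units; that floor lies within the scatter) from compound 3 to compound 4; the limit leaves it open whether they differ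

Going by these compounds, it remains open how far compound 4 lies past its limit. On these data alone, it is also open how an amine or a longer chain such as ethylsulfanyl in place of methoxy would read on either core.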